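The source may report more compounds than this note shows. Statements on the series, on what has been measured and on what is new or still open speak of the compounds shown alone.

Measured compounds:
compound 1 `COC(=O)C1=C(C)N(C)C(=O)NC1c1cccs1`: 15%
compound 2 `CCOC(=O)C1=C(C)N(C)C(=O)NC1c1cccs1`: 2%
compound 3 `CCC(CC)OC(=O)C1=C(C)NC(=O)NC1c1ccco1`: 1%

All three were run in an assay on membranes from HeLa cells for displacement of a labelled ligand from adenosine receptor A3 (Homo sapiens), read by scintillation counting, with a stated time of 180 min, tested at 1 uM; a lower number here means less inhibition, a higher number more inhibition at the concentration tested (going by the name of the read-out). In this assay compound 1 gives 15%, compound 2 gives 2% and compound 3 gives 1%. Among the measured compounds shown here, the one counted change between measured compounds is hydrogen in place of methyl on a saturated chain carbon bound to an oxygen next to a carbonyl group, and it moves the read-out by a number 13 percentage points higher from compound 2 to compound 1 (beyond the scatter). Compound 3 and compound 2 differ in more than one place; how the two cores differ is not broken down here, and their values lie within the scatter of each other.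

Compound 4 `CCC(C)OC(=O)C1=C(C)NC(=O)NC1c1ccco1` is not yet measured. It differs from compound 3 by hydrogen in place of methyl on a saturated chain carbon, two bonds along the chain from an oxygen next to a carbonyl group. For the measured compounds named here, this is the same kind of change as the one from compound 2 to compound 1, but not the same: there the place is a saturated chain carbon bound to an oxygen next to a carbonyl group, here it is a saturated chain carbon two bonds along the chain from an oxygen next to a carbonyl group, and the core of compound 3 is not the core of compound 2.

For compound 4 the step from compound 3 is expected to be a number 5 percentage points higher from compound 3 to compound 4 (within the scatter), smaller than the earlier one, because compound 3 starts from 1% and the change sits one bond further out on a different core. The estimate for compound 4 in this assay is 6%, with a range from -6% to 20%.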

Compound 4, a percentage reported as inhibition, at one concentration (the size of the read-out at that concentration, not a potency): 3%
Beside the measured number, compound 4's estimate is 3 percentage points above it, and the stated range covers the measured number.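

In this assay, hydrogen in place of methyl at this place gives a number 2 percentage points higher from compound 3 to compound 4 (within the scatter), and set beside the earlier step the two results do not separate: the same change on two cores in this assay, a number 13 percentage points higher (beyond the scatter) from compound 2 to compound 1 and a number 2 percentage points higher (within the scatter) from compound 3 to compound 4, 11 percentage points apart, within the scatter of two such steps

This gives no ground for saying that the core alters the effect of the change. Nor does it show that the change carries over, since only the earlier step lies beyond the scatter and the new one lies within it, so the new step alone shows no effect of the change on its core. The two steps also sit at different places, a saturated chain carbon bound to an oxygen next to a carbonyl group in one case and a saturated chain carbon two bonds along the chain from that oxygen in the other, and two pairs cannot separate the core from the place.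

The compounds shown leave open how the read-out responds on either core to a longer chain, or to an amine or a carboxylic acid at the end of the chain. Also open, from the compounds shown here alone, is how the change behaves at both places on a single core, a comparison that would tell the place apart from the core.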